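Urea for Amide: Expecting Cytotoxicity of Compound 3

This account rests on a few compounds, and the source may have more. Where it says the series, first, only, none or still open, it means among the compounds named here.

Compound 1 `NC(=O)c1ccc2c(ccn2-c2ccc(NC(=O)c3cccc(C(F)(F)F)c3)cc2)n1` was tested in an ADME assay on HS27 cells (Homo sapiens) for cytotoxicity, read by MTT assay; a lower number here means a stronger inhibitor, a higher number a weaker inhibitor. In this assay compound 1 gives only a limit, > 10000 nM, not a number. Compound 2 `COC(=O)c1ccc2c(ccn2-c2ccc(NC(=O)c3cccc(C(F)(F)F)c3)cc2)n1` in this assay gives 9800 nM. The step of an at least 1.0-fold lower number from compound 1 to compound 2 (0.00 log units; that floor lies within the scatter) carries a floor rather than a size because of the limit of > 10000 nM in this assay, at which 1 of the 2 values shown sits. Compound 3 `NC(=O)c1ccc2c(ccn2-c2ccc(NC(=O)Nc3ccc(Cl)c(Cl)c3)cc2)n1` has not yet been measured in this assay. It differs from compound 1 by (3,4-dichlorophenyl)amino in place of 3-(trifluoromethyl)phenyl on a carbonyl carbon. Going by the values given here, the single measured step, from compound 1 to compound 2, touched a different place and stayed within the scatter, so it gives no direction for the change that leads to compound 3. Compound 3 is therefore expected to show no step beyond the scatter, a number no higher from compound 1 to compound 3 (the limit leaves the size open). Compound 3 in this assay is estimated at 10000 nM, within 4000 nM to 30000 nM, with a fair chance that the assay again reports only a limit.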

Compound 3, half-maximal inhibitory concentration: 6600 nM
Compound 3: middle estimate off by 1.5-fold (0.18 log units), on the high side, and the stated range covers the measured number.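

With (3,4-dichlorophenyl)amino in place of 3-(trifluoromethyl)phenyl on a carbonyl carbon, this assay shows an at least 1.5-fold lower number from compound 1 to compound 3 (0.18 log units; that floor lies within the scatter). Going by these compounds alone, this is the first reading at this position, and here compound 3 gives a number, 6600 nM. The true size of the step stays unknown, and it cannot be said whether the change has any real effect, because one end of it is only a limit: the limit of > 10000 nM in this assay, at which 1 of the 3 values shown sits.

The compounds shown do not separate the entering amino nitrogen from the two chlorine atoms, as both arrive in one change. Going by these compounds, it also remains open how a 3,4-dichlorophenyl group set directly on that carbonyl carbon, or a 3-(trifluoromethyl)phenylamino group, would read in this assay.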